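The source may hold more compounds than are shown below. What is called first, only, known or untested is meant among the compounds shown, and "the series" means these compounds.

Measured so far:
Compound 1 `C=CC1=C(C(=O)Nc2ccccc2OC)C(c2ccc(F)cc2)OC1` gives 52800 nM in a functional assay on QGY7701 cells (Homo sapiens) for cytotoxicity, read by MTT assay, with a stated time of 24 h; a lower number here means a stronger inhibitor, a higher number a weaker inhibitor.
Compound 2 `C=CC1=C(C(=O)NCc2ccc(Cl)cc2)C(c2ccc(OC)cc2)OC1` reaches only the limit of this assay, > 100000 nM.

Compound 2 thus stands at the limit (the limit of > 100000 nM in this assay, at which 1 of the 2 values shown sits), with no number of its own. Compound 3 `C=CC1=C(C(=O)Nc2ccccc2OC)C(c2ccc(OC)cc2)OC1` differs from compound 2 by 2-methoxyphenyl in place of 4-chlorobenzyl on an amide-type nitrogen. Within the data shown here, no measured pair shows this change, so its size is open, but compound 1, which carries the same amide substituent, gives 52800 nM in this assay. Compound 3 is therefore expected to move downward into the measurable range, an at least 1.4-fold lower number from compound 2 to compound 3 (0.15 log units; that floor lies within the scatter). The estimate for compound 3 is 70000 nM, within 25000 nM to 200000 nM.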

Compound 3, half-maximal inhibitory concentration: > 100000 nM
Compound 3: only a limit was reported; the forecaster's own chance of this, stated with the estimate: 40%; middle value at least 1.4-fold (0.15 log units) from the limit.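

With 2-methoxyphenyl held on the amide-type nitrogen, methoxy in place of fluoro on an aromatic carbon gives an at least 1.8-fold higher number from compound 1 to compound 3 (0.27 log units; that floor lies within the scatter). That amide substituent therefore does not by itself yield a measurable number in this assay, and the step between compound 2 and compound 3 joins two limits and cannot be read. Limits now make up most of the values shown: the limit of > 100000 nM in this assay, at which 2 of the 3 values shown sit.

On these data alone, how far compound 3 lies past its limit stays open, and so does whether this change exceeds the usual scatter. Also open, as far as these compounds go, is what a hydroxyl or nitrile group on that aromatic carbon would give.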